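Notes on compound 3, an aryl ether variant, before testing

The compounds below may be only part of what the source reports. "The series", "measured", "known", "first", "only" and "open" are said of these compounds alone.

Measured so far in a functional assay on ME-180 cells (Homo sapiens) for cytotoxicity, read by MTT assay, with a stated time of 72 h; a higher number here means a weaker inhibitor, a lower number a stronger inhibitor:
- compound 1, `COc1ccc(/C=C/C(=O)Nc2cc(C(=O)c3cc(OC)c(OC)c(OC)c3)cc(OC)c2OC)cc1OC`: 6700 nM
- compound 2, `COc1ccc(/C=C/C(=O)Nc2cc(C(=O)c3cc(OC)c(OC)c(OC)c3)cc(OC)c2OC)cc1`: 12500 nM
- compound 3, `C#CCOc1cccc(/C=C/C(=O)Nc2cc(C(=O)c3cc(OC)c(OC)c(OC)c3)cc(OC)c2OC)c1`: not yet measured

Among the measured compounds shown here, compound 2 gives 12500 nM in this assay, and compound 1 gives 6700 nM; the only step between them, a 1.9-fold higher number from compound 1 to compound 2 (0.27 log units; within the scatter), does not separate the two.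

Compound 3 differs from compound 2 by 3-(propargyloxy)phenyl in place of 4-methoxyphenyl on a double-bonded chain carbon bound to a double-bonded chain carbon. For the measured compounds named here, the one measured step that touches this part of the molecule is the removal of a methoxy from the same aryl ring, a 1.9-fold higher number from compound 1 to compound 2 (0.27 log units; within the scatter), which stayed within the scatter. Going by the values given here, no measured step covers a propargyloxy group or a shift of the ether to the position named above, so the direction of any effect is unknown. On what is known, no step beyond the scatter is expected in this assay, and the step from compound 2 to compound 3 is estimated as a 1.0-fold lower number from compound 2 to compound 3 (0.02 log units; within the scatter). Compound 3 is therefore expected at 12000 nM, with a range of 4000 nM to 40000 nM.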

Compound 3, half-maximal inhibitory concentration: 8400 nM
Compound 3: middle estimate off by 1.4-fold (0.15 log units), on the high side, and the stated range covers the measured number.
By their numbers in this assay, from the lowest: compounds 1, 3 and 2 (each within the scatter of the next).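

In this assay, 3-(propargyloxy)phenyl in place of 4-methoxyphenyl on a double-bonded chain carbon bound to a double-bonded chain carbon gives a 1.5-fold lower number from compound 2 to compound 3 (0.17 log units; within the scatter), and the same group in place of 3,4-dimethoxyphenyl gives a 1.3-fold higher number from compound 1 to compound 3 (0.10 log units; within the scatter). The earlier compounds shown here showed only the loss of one methoxy at this place, whereas these steps show that a group of 10 heavy atoms carrying a triple bond, replacing the 8 heavy atoms of 4-methoxyphenyl, also produces no step beyond the scatter. No supporting data bear on this result.

Compound 3 changes both the place of the ether on the phenyl group and the chain on its oxygen, so the contribution of each cannot be read separately, and all three compounds remain within the scatter of one another. On these data alone, it remains open whether an amine, a carboxylic acid or a longer chain on the oxygen at this place would produce a step beyond the scatter, or whether this place influences the cytotoxicity read-out at all.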